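Methyl on the terminal ring of a biaryl benzimidazole sulfone

This account rests on a few compounds, and the source may have more. Where it says the series, first, only, none or still open, it means among the compounds named here.

Of the compounds shown here, two have been measured in an assay on isolated protein for inhibition of acyl-CoA desaturase 1 (Rattus norvegicus); on this read-out higher numbers stand for weaker inhibition and lower numbers for stronger inhibition. Compound 1 `NS(=O)(=O)c1ccc2nc(-c3ccc(-c4ccccc4F)cc3)[nH]c2c1` gives 343 nM. Compound 2 `CS(=O)(=O)c1ccc2nc(-c3ccc(-c4ccccc4)cc3)[nH]c2c1` gives 20 nM. Among the compounds with values here, compound 2 thus stands lowest of the two numbers, and the gap to compound 1 lies beyond the scatter of repeated measurements, so compound 2 is the more potent of the pair; what separates compound 1 from compound 2 is not a single change, and no step between them is recorded.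

Compound 3 `Cc1ccc(-c2ccc(-c3nc4ccc(S(C)(=O)=O)cc4[nH]3)cc2)cc1` is not yet measured in this assay. It differs from compound 2 in one place: methyl in place of hydrogen on an aromatic carbon. Within the data shown here, no measured pair shows this change, so its size rests on expectation alone. A small step is expected from compound 2 to compound 3, a 1.3-fold lower number from compound 2 to compound 3 (0.12 log units; within the scatter), not clearly beyond the scatter. For compound 3 the estimated value in this assay is 15 nM, with a range from 5 nM to 50 nM.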

Compound 3, half-maximal inhibitory concentration: > 20000 nM
Compound 3 was reported as a limit; the forecaster's own chance of this, stated with the estimate: 2%; middle value at least 1300-fold (3.12 log units) away from the limit.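

In this assay, compound 3 stands only as a limit, not as a number: the limit of > 20000 nM in this assay, at which 1 of the 3 values shown sits.

Methyl in place of hydrogen on an aromatic carbon, para to a large group, brings an at least 1000-fold higher number from compound 2 to compound 3 (3.00 log units; beyond the scatter). Within the data shown here, this is the first single-place step, and it shows that one added carbon at this position is enough to take the compound from strong inhibition to the limit of the read-out, which the two earlier compounds, differing in more than one place, could not show.

From the compounds shown here alone, it remains open whether fluorine, a methoxy group or an amine at the same place would keep the potency of compound 2, at 20 nM, or whether any replacement of this hydrogen is poorly accepted. Also open, going by these compounds, is whether methyl elsewhere on the same ring would bring a step of similar size.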